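Swapping a Methoxyphenyl for a Methylphenyl

The source may hold more compounds than are shown below. What is called first, only, known or untested is meant among the compounds shown, and "the series" means these compounds.

Four compounds share one core and differ only in the group on the benzylic carbon. Compound 1 `COC(=O)c1ccc(NCc2cncn2Cc2ccccc2N)cc1-c1ccccc1` is the only one with a result: in a toxicity assay on NIH3T3 cells (Mus musculus) for cytotoxicity, read by resazurin assay (on this read-out higher numbers stand for an effect only at larger amounts of compound and lower numbers for an effect already at smaller amounts), compound 1 gives 25000 nM. For compound 2 `COC(=O)c1ccc(NCc2cncn2Cc2cccc(OC)c2)cc1-c1ccccc1` the entry in this assay reads "not determined" (no result reported). Compound 3 `COC(=O)c1ccc(NCc2cncn2Cc2ccccc2OC)cc1-c1ccccc1` likewise stands without a number: in this assay compound 3 gives "not determined" (no result reported), so it and compound 2 are the two entries lacking a result. Compound 4 `COC(=O)c1ccc(NCc2cncn2Cc2ccc(C)cc2)cc1-c1ccccc1` carries the change (4-methylphenyl in place of 2-methoxyphenyl on a saturated chain carbon bound to an aromatic nitrogen). Nothing measured links the two, so the step is expected to be small, no larger than the usual scatter, with no clear direction. Compound 4 is therefore estimated at 25000 nM, likely between 8000 nM and 80000 nM, resting on the reading of compound 1.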

Compound 4, half-maximal effective concentration: 50000 nM
Beside the measured number, compound 4's estimate is 2.0-fold (0.30 log units) below it; measured number inside the range.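

In this assay, among the compounds shown here, the one readable comparison at this place is a 2.0-fold higher number from compound 1 to compound 4 (0.30 log units; within the scatter), so on a saturated chain carbon bound to an aromatic nitrogen, 2-aminophenyl and 4-methylphenyl cannot be told apart. Both compounds remain in the same range despite carrying different groups on their rings. No supporting data bear on this result.

Steps involving compound 2 or compound 3, including the swap of 2-methoxyphenyl for 4-methylphenyl, cannot be read. From the compounds shown here alone, whether a carboxylic acid or a longer chain at this place would give a clearly different reading remains open.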